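Swapping a Benzyl for an Aryl on Sulfur

A few compounds are considered here, and "the series" means these few. Any claim that something is new, unique, unknown or untested is made for them only; others in the source may bear on it.

Measured compounds:
compound 1 `Cc1ccc(CS/C(=C/c2ccc(Cl)c([N+](=O)[O-])c2)C(=O)c2ccc(C(=O)O)cc2)cc1` — 1000 nM
compound 2 `O=C(/C(=C\c1ccc(O)c([N+](=O)[O-])c1)SCc1ccccc1Cl)c1ccc(Cl)cc1` — 10000 nM
compound 3 `COc1ccccc1/C=C(/SCc1ccc(F)cc1)C(=O)c1ccc(Br)cc1` — 10000 nM

Of the compounds shown here, three have been tested in a functional assay on DU-145 cells (Homo sapiens) for inhibition, read by trypan blue exclusion, with a stated time of 96 h; a higher number here means a weaker inhibitor of growth, a lower number a stronger inhibitor of growth. Compound 2 gives 10000 nM. Compound 3 gives 10000 nM, the same number at the digits shown, so the two sit level within the usual scatter and no order can be drawn between them; together they carry the highest numbers of the set. Compound 1 gives 1000 nM, a clearly lower number, beyond the scatter, so compound 1 is the strongest growth inhibitor of the three.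

The unmeasured compound 4 `Cc1ccc(S/C(=C/c2ccc(O)c([N+](=O)[O-])c2)C(=O)c2ccc(Cl)cc2)cc1` differs from compound 2 in one place: 4-methylphenyl in place of 2-chlorobenzyl on a sulfur. Within the data shown here, no measured pair shares this change, so the data give no direct guide to its effect. The expected step, a 2.0-fold lower number from compound 2 to compound 4 (0.30 log units; within the scatter), is modest and leans toward a lower number, held loosely. Compound 4 is estimated at 5000 nM, with a range from 1500 nM to 20000 nM.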

Compound 4, concentration for 50% growth inhibition: 10000 nM
Compound 4: the middle estimate sits 2.0-fold (0.30 log units) below what was measured; the measured number falls inside the stated range.
By their numbers in this assay, from the lowest: compound 1; then compounds 2, 3 and 4 (each within the scatter of the next).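

Among these compounds, putting 4-methylphenyl in place of 2-chlorobenzyl on the sulfur gives no change at the digits printed from compound 2 to compound 4 (within the scatter) in this assay and supplies the first measured step at this position. In this one pair, a benzyl and an aryl group on the sulfur cannot be told apart by this read-out, so the swap does not offer a route to a lower number. Nothing available explains why the two compounds read alike.

The swap alters the ring's link to the sulfur, removes the chlorine and adds the methyl all at once, so this single step cannot show whether each change alone would be silent or whether they offset one another. From the compounds shown here alone, whether a longer chain such as phenylethyl on this sulfur, or an amine on its ring, would shift the number remains open.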